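Swapping hydroxy for amino on a weak inhibitor

A few compounds are considered here, and "the series" means these few. Any claim that something is new, unique, unknown or untested is made for them only; others in the source may bear on it.

Compound 1 `COc1cc(O)cc(O)c1C(=O)/C=C/c1ccc(C(F)(F)F)cc1` gives 9500 nM
Compound 2 `COc1cc(OC)c(C(=O)/C=C/c2ccc(O)cc2)c(OC)c1` gives 40600 nM

In a functional assay on HeLa cells (Homo sapiens) for inhibition, read by MTT assay, with a stated time of 72 h (a higher number here means a weaker inhibitor, a lower number a stronger inhibitor), compound 2 stands at 40600 nM and has the higher of the two numbers, which makes it the weaker inhibitor. Its gap from compound 1 lies beyond the scatter of repeat measurements. These two compounds differ in more than one place, so their gap cannot be tied to any single group.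

The next compound is compound 3 `COc1cc(OC)c(C(=O)/C=C/c2ccc(N)cc2)c(OC)c1`, which keeps the structure of compound 2 except at one spot. It has amino in place of hydroxy on an aromatic carbon, para to a large group (amino in place of hydroxy on an aromatic carbon). In other words, 4-hydroxyphenyl becomes 4-aminophenyl.

Among the compounds with values here, no measured pair shows this swap, so the direction is a cautious guess. A modest fall in the number is expected, only a little beyond the scatter. The estimated change is a 2.3-fold lower number from compound 2 to compound 3 (0.35 log units; beyond the scatter) in this assay and remains uncertain. Compound 3 is expected at 18000 nM with an estimated range from 5000 nM to 50000 nM in this assay when it is measured.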

Compound 3, half-maximal inhibitory concentration: > 50000 nM
Compound 3 gave a limit, no number; the forecaster's own chance of this, stated with the estimate: 3%; middle value at least 2.7-fold (0.44 log units) away from the limit.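

Compound 3 gives no number in this assay, only a limit of > 50000 nM. Read as a step, replacing hydroxy with amino gives an at least 1.2-fold higher number from compound 2 to compound 3 (0.09 log units; that floor lies within the scatter), so the modest fall in the number does not appear, although that floor alone cannot show a real rise. At this position on the aromatic ring, para to a large group, this single pair therefore shows no gain from amino over hydroxy, even though the two groups differ by only one heavy atom and match in their counted hydrogen-bond donors and acceptors.

Going by these compounds, whether amino costs little or a great deal compared with hydroxy cannot be told, because the reading for compound 3 stops at a limit: the limit of > 50000 nM in this assay, at which 1 of the 3 values shown sits. Also open is how the core of compound 2 would respond to a different group at this same place, such as a fluorine atom or a carboxylic acid, and whether either could bring the number down rather than leave it this high.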